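The compounds below may be only part of what the source reports. "The series", "measured", "known", "first", "only" and "open" are said of these compounds alone.

Measured compounds in an assay on isolated protein for inhibition of mitogen-activated protein kinase kinase kinase 14 (Homo sapiens), read by ADP-Glo, with a stated time of 60 min, tested at 100 uM, in the presence of a further agent that is not named here; a higher number here means more inhibition at the concentration tested (going by the name of the read-out), a lower number less inhibition:
compound 1 `O=C(Nc1cc(C(F)(F)F)cc(C(F)(F)F)c1)c1nsnc1O` gives 4.34%;
compound 2 `COc1nsnc1C(=O)Nc1cc(C(F)(F)F)cc(C(F)(F)F)c1` gives -1.9%;
compound 3 `Cn1nnc(O)c1C(=O)Nc1cc(C(F)(F)F)cc(C(F)(F)F)c1` gives 12.1%.

Compound 3 holds the highest of the three numbers, separated from compound 1 by a number 7.8 percentage points higher from compound 1 to compound 3 (within the scatter) and from compound 2 by a number 14 percentage points higher from compound 2 to compound 3 (beyond the scatter).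

Compound 4 `O=C(Nc1cc(C(F)(F)F)cc(C(F)(F)F)c1)c1n[nH]nc1O` differs from compound 3 by 5-hydroxy-2H-1,2,3-triazol-4-yl in place of 4-hydroxy-1-methyl-1H-1,2,3-triazol-5-yl on a carbonyl carbon. Two measured steps exchange the ring on the carbonyl carbon: a number 7.8 percentage points higher from compound 1 to compound 3 (within the scatter) and a number 14 percentage points higher from compound 2 to compound 3 (beyond the scatter), only the second going beyond the scatter and then modestly. Within the data shown here, the one measured exchange of a methyl for a hydrogen, a number 6.2 percentage points lower from compound 1 to compound 2 (within the scatter), stays within the scatter. No step beyond the scatter is therefore expected for compound 4 in this assay; the expected step is a number 2.1 percentage points lower from compound 3 to compound 4 (within the scatter). Compound 4 is estimated at 10%, between -2% and 22%.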

Compound 4, a percentage reported as inhibition, at one concentration (the size of the read-out at that concentration, not a potency): -9.5%
For compound 4 the middle estimate is 19.5 percentage points above the measured one, outside the stated range (below it).
By their numbers in this assay, from the lowest: compounds 4, 2, 1 and 3 (each within the scatter of the next, the first and the last beyond it).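

On the carbonyl carbon, removing the ring methyl of compound 3 is not neutral in this assay: a number 21.6 percentage points lower from compound 3 to compound 4 (beyond the scatter), the largest ring exchange seen at this position. Against the sulfur-containing rings the outcome splits, with a number 13.8 percentage points lower from compound 1 to compound 4 (beyond the scatter), while a number 7.6 percentage points lower from compound 2 to compound 4 (within the scatter). Nothing available explains these differences.

Going by these compounds, whether the methyl of compound 3 is the feature that matters remains open, and an ethyl in its place would test this. Also open, on these data alone, is whether an amine in place of the hydroxy would change the reading.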